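The compounds below may be only part of what the source reports. "The series", "measured", "known", "first", "only" and "open" are said of these compounds alone.

Compound 2 `COc1cc(-c2nn(-c3cccc(NC(=O)Nc4cc(C(F)(F)F)cc(C(F)(F)F)c4)c3)cc2-c2ccncc2)ccc1Cl` is the compound that gives the lower of the two numbers available here: in a functional assay on MDA-MB-231 cells (Homo sapiens) for inhibition, read by sulforhodamine B assay, with a stated time of 48 h (on this read-out higher numbers stand for weaker inhibition of growth and lower numbers for stronger inhibition of growth), compound 2 gives 1410 nM. The only comparator, compound 1 `O=C(Nc1cccc(-n2cc(-c3ccncc3)c(-c3ccc(Cl)c(O)c3)n2)c1)Nc1cccc(C(F)(F)F)c1`, differs from it in more than one place, and in this assay compound 1 gives 26800 nM, a higher number that lies beyond the usual scatter of such measurements. Two features change at once between these two compounds. Their values alone do not show how much of that gap belongs to either feature.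

Compound 3 `O=C(Nc1cccc(-n2cc(-c3ccncc3)c(-c3ccc(Cl)c(O)c3)n2)c1)Nc1cc(C(F)(F)F)cc(C(F)(F)F)c1` takes one of those features from compound 1 and keeps the other from compound 2: relative to compound 2 the change is hydrogen in place of methyl on an oxygen on an aromatic ring, so that the 4-chloro-3-methoxyphenyl group becomes 4-chloro-3-hydroxyphenyl.

Since compound 1, which also carries the hydroxy group, gives the higher value 26800 nM, compound 3 is expected to move toward a higher number, with a step from compound 2 to compound 3 of about a 3.2-fold higher number from compound 2 to compound 3 (0.50 log units; beyond the scatter). The estimate for compound 3 in this assay is 4500 nM, with a range from 1200 nM to 17000 nM.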

Compound 3, concentration for total growth inhibition: 1660 nM
Beside the measured number, compound 3's estimate is 2.7-fold (0.43 log units) above it, and the stated range covers the measured number.
By their numbers in this assay, from the lowest: compounds 2 and 3 (each within the scatter of the next); then compound 1.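

In this assay, the exchange of methoxy for hydroxy on the 4-chloro-3-methoxyphenyl group gives a 1.2-fold higher number from compound 2 to compound 3 (0.07 log units; within the scatter), so with the urea partner of compound 2 kept in place, this oxygen tolerates either a methyl or a hydrogen without a readable difference. The earlier pair could not show this, since two features changed at once; compound 3 separates them and places the large gap at the other feature, trifluoromethyl in place of hydrogen on an aromatic carbon, which gives a 16-fold lower number from compound 1 to compound 3 (1.21 log units; beyond the scatter). No measurement given here explains why that trifluoromethyl group matters so much while the change on the oxygen does not.

Among these compounds, still open is whether methoxy and hydroxy would also match in the presence of only the single trifluoromethyl group of compound 1, as the pair of compounds 2 and 3 tests this only with the added group present. The compounds shown also leave open how an amine or a longer chain such as ethoxy in place of the hydroxy would read, and whether a chlorine or a methyl could stand in for the added trifluoromethyl.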